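The compounds below may be only part of what the source reports. "The series", "measured", "known", "first", "only" and "open" are said of these compounds alone.

Measured compounds in an ADME assay on Vero cells (Chlorocebus sabaeus) for cytotoxicity, read by MTT assay, with a stated time of 72 h; on this read-out higher numbers stand for lower toxicity in this test and lower numbers for higher toxicity in this test:
- compound 1 `COc1c(N2CCN(CC#N)C(C)C2)c(F)cc2c(=O)c(C(=O)O)cn(C3CC3)c12`: 354 ug/mL
- compound 2 `COc1c(N2CCN(C/C(C)=N/NC(C)=O)C(C)C2)c(F)cc2c(=O)c(C(=O)O)cn(C3CC3)c12`: 707 ug/mL
- compound 3 `COc1c(N2CCN(C/C(C)=N/Nc3ccccc3)C(C)C2)c(F)cc2c(=O)c(C(=O)O)cn(C3CC3)c12`: 11.1 ug/mL

Among these three numbers compound 1 stands second highest. Its nearest neighbour is compound 2, reached by a 2.0-fold higher number from compound 1 to compound 2 (0.30 log units; within the scatter); the furthest is compound 3, reached by a 32-fold lower number from compound 1 to compound 3 (1.50 log units; beyond the scatter). The gap between compound 2 and compound 3 is a 64-fold lower number from compound 2 to compound 3 (1.80 log units; beyond the scatter).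

Compound 4 `COc1c(N2CCN(CC/C(C)=N/O)C(C)C2)c(F)cc2c(=O)c(C(=O)O)cn(C3CC3)c12` differs from compound 1 as follows: a group of 5 heavy atoms (3 carbon, 1 nitrogen, 1 oxygen; no ring) in place of a group of 2 heavy atoms (1 carbon, 1 nitrogen; no ring), on a saturated chain carbon bound to an amine nitrogen in a ring

The two steps that bear on this change are the two that replace the cyano on the same chain carbon. The step to compound 2 brought in a group with no ring and stayed within the scatter, whereas the step to compound 3 brought in a six-membered aromatic ring of carbon only and gave a large drop. The entering group of compound 4 carries no ring and is closer in size to what compound 2 bears than to what compound 3 bears, so on the evidence of a 2.0-fold higher number from compound 1 to compound 2 (0.30 log units; within the scatter) compound 4 is expected to sit near compound 1, with no step beyond the scatter: the expected step is a 1.0-fold lower number from compound 1 to compound 4 (0.00 log units; within the scatter).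

For compound 4 in this assay the estimated value is 350 ug/mL, expected between 150 ug/mL and 750 ug/mL.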

Compound 4, half-maximal cytotoxic concentration: 44.2 ug/mL
Compound 4: the middle estimate sits 7.9-fold (0.90 log units) above what was measured; measured number outside the range, below it.
By their numbers in this assay, from the lowest: compound 3; then compound 4; then compounds 1 and 2 (each within the scatter of the next).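

In this assay, a step of an 8.0-fold lower number from compound 1 to compound 4 (0.90 log units; beyond the scatter) shows that a group with no ring, placed on a saturated chain carbon bound to an amine nitrogen in a ring, can still take the number down beyond the scatter. The absence of a ring therefore does not settle the outcome at this position: the two ring-free groups are separated by a 16-fold lower number from compound 2 to compound 4 (1.20 log units; beyond the scatter) and, with a 4.0-fold higher number from compound 3 to compound 4 (0.60 log units; beyond the scatter) as well, the group carrying the aromatic ring remains distinct from the newest ring-free one. No measurement at hand accounts for this ordering of the groups.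

Open, going by these compounds, is which part of the entering group in compound 4 goes with the lower number, its hydroxyl or its chain. A methoxy in place of that hydroxyl, or a plain propyl chain at the same place, would separate the two.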